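The source may report more compounds than this note shows. Statements on the series, on what has been measured and on what is new or still open speak of the compounds shown alone.

Compound 1 `COc1cc(-n2c(-c3ccc(O)cc3)c[nH]c2=O)cc(OC)c1OC` is a phenol on a shared core, and in a functional assay on PC-3 cells (Homo sapiens) for cytotoxicity, read by MTT assay, with a stated time of 48 h (a lower number here means a stronger inhibitor, a higher number a weaker inhibitor), compound 1 gives 30200 nM. Compound 2 `COc1ccc(-c2c[nH]c(=O)n2-c2cc(OC)c(OC)c(OC)c2)cc1` carries the change (methyl in place of hydrogen on an oxygen on an aromatic ring), and in this assay compound 2 gives > 50000 nM, which is a limit of the assay (the limit of > 50000 nM in this assay, at which 1 of the 3 values shown sits). The step between them, an at least 1.6-fold higher number from compound 1 to compound 2 (0.21 log units; that floor lies within the scatter), therefore reads as a floor only. Compound 3 `COc1cc(NC(=O)n2cc(-c3ccc(O)cc3)n(-c3cc(OC)c(OC)c(OC)c3)c2=O)cc(OC)c1OC` adds a larger piece to the core of compound 1; the difference between the two cores is not broken down here. In this assay, within the data shown here, compound 3 gives 3000 nM, the lowest of the two numbers known, and its gap from compound 1 lies beyond the scatter. Compound 4 `COc1ccc(-c2cn(C(=O)Nc3cc(OC)c(OC)c(OC)c3)c(=O)n2-c2cc(OC)c(OC)c(OC)c2)cc1` is not yet measured; it differs from compound 3 by methyl in place of hydrogen on an oxygen on an aromatic ring, the same change seen from compound 1 to compound 2 at the same place. Since that earlier step reached at least a floor toward a weaker number, a step of a 2.3-fold higher number from compound 3 to compound 4 (0.37 log units; beyond the scatter) is expected here, resting on compound 2 at > 50000 nM and compound 1 at 30200 nM. Compound 4 is accordingly estimated at 7000 nM, between 2500 nM and 25000 nM.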

Compound 4, half-maximal inhibitory concentration: 49700 nM
Compound 4: the middle estimate sits 7.1-fold (0.85 log units) below what was measured; the whole stated range lies below it.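

In this assay, methyl in place of hydrogen on the oxygen gives a large step on the core of compound 3, a 17-fold higher number from compound 3 to compound 4 (1.22 log units; beyond the scatter), so on this pair the change from 4-hydroxyphenyl to 4-methoxyphenyl goes with a clearly weaker number. On the core of compound 1, compound 2 gives > 50000 nM, which is a limit of the assay and not a number. The result therefore shows that the change can cost much on one core, but it does not show whether the change carries over to the other core with the same size: the same change on two cores in this assay, an at least 1.6-fold higher number (0.21 log units; that floor lies within the scatter) from compound 1 to compound 2 and a 17-fold higher number (1.22 log units; beyond the scatter) from compound 3 to compound 4; the limit leaves it open whether they differ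

The compounds shown leave open how the series would read with a longer chain on that oxygen, such as ethyl, or with an amine in place of the hydroxy group. Among these compounds, with only two pairs in hand, they also leave open whether a step of this size would recur on any further core.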